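From methylsulfanyl to trifluoromethoxy: compound 2 to compound 3

A few compounds are considered here, and "the series" means these few. Any claim that something is new, unique, unknown or untested is made for them only; others in the source may bear on it.

Measured in an ADME assay on microsomes from liver (Homo sapiens) for metabolic stability, read by LC-MS, with NADPH named in the record, with a stated time of 60 min, tested at 1 uM, in the absence of a further agent; a higher number here means that more of the compound is left, a lower number that less of the compound is left:
Compound 1 `CC(=O)N[C@@H]1CCN(c2cc(C)nn3c(-c4ccc(C(F)(F)F)cc4)c(C)nc23)C1`: > 95%
Compound 2 `CSc1ccc(-c2c(C)nc3c(N4CC[C@@H](NC(C)=O)C4)cc(C)nn23)cc1`: > 95%

The value of compound 2, > 95%, is a limit of the assay and not a number. The value of compound 1, > 95%, is a limit as well. Compound 3 `CC(=O)N[C@@H]1CCN(c2cc(C)nn3c(-c4ccc(OC(F)(F)F)cc4)c(C)nc23)C1` has not yet been measured. It departs from compound 2 on an aromatic carbon of a six-membered aromatic ring of carbon only, para to a large group: trifluoromethoxy in place of methylsulfanyl on an aromatic carbon. Among the measured compounds shown here, the one measured step, a step that the two limits leave unreadable from compound 1 to compound 2, involves that same carbon, but it offers no size to carry over. What remains is the limit of > 95% in this assay, at which 2 of the 2 values shown sit, shared by compound 1 and compound 2, so no step beyond the scatter is expected in this assay. The expected step is a number no higher from compound 2 to compound 3 (the limit leaves the size open). For compound 3 the estimated value is 95%, with an expected range from 85% to 100%.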

Compound 3, percent of the compound remaining: > 95%
Compound 3: no number, only a limit; the forecaster's own chance of this, stated with the estimate: 55%; the middle value lies on the limit itself.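

In this assay, among the compounds shown here, compound 3 gives > 95%, a limit and not a number, and no step from compound 1 or compound 2 to compound 3 can be read. The compounds shown leave open whether these three differ at all in the percent remaining: the limit of > 95% in this assay, at which 3 of the 3 values shown sit.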